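The compounds below may be only part of what the source reports. "The series", "measured", "known", "first", "only" and "open" are said of these compounds alone.

Of the compounds shown here, three on a shared core have been measured in a functional assay on HCT-116 cells (Homo sapiens) for cytotoxicity, read by MTT assay, with a stated time of 48 h; a higher number here means a weaker inhibitor, a lower number a stronger inhibitor. Compound 1 `O=C(Nc1ccccc1)c1cn(-c2ccccc2)nc1-c1ccc(Cl)cc1` gives 2180 nM. Compound 2 `O=C(Nc1ccc(Br)cc1)c1cn(-c2ccccc2)nc1-c1ccc(Cl)cc1` differs from compound 1 by bromo in place of hydrogen on an aromatic carbon. In this assay compound 2 gives 4360 nM; the step of a 2.0-fold higher number from compound 1 to compound 2 (0.30 log units; within the scatter). Compound 3 `O=C(Nc1ccccc1)c1cn(-c2ccccc2)nc1-c1ccc([N+](=O)[O-])cc1` has a core that differs from that of compound 1 by nitro in place of chloro on an aromatic carbon. In this assay compound 3 gives 2010 nM; the step of a 1.1-fold lower number from compound 1 to compound 3 (0.04 log units; within the scatter). Compound 4 `O=C(Nc1ccc(Br)cc1)c1cn(-c2ccccc2)nc1-c1ccc([N+](=O)[O-])cc1` is not yet measured; it differs from compound 3 by bromo in place of hydrogen on an aromatic carbon, the same change as from compound 1 to compound 2, made in the same place, and occurring twice among these compounds. For compound 4 the step of a 2.0-fold higher number from compound 3 to compound 4 (0.30 log units; within the scatter) in this assay is expected, since it rests on the step of a 2.0-fold higher number from compound 1 to compound 2 (0.30 log units; within the scatter) seen on the other core. Compound 4 is thus estimated at 4000 nM, between 2000 nM and 8000 nM.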

Compound 4, half-maximal inhibitory concentration: 4080 nM
The estimate for compound 4 lay 1.0-fold (0.01 log units) below the measured number; measured number inside the range.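

The change from anilino to (4-bromophenyl)amino read the same on both cores in this assay, with a 2.0-fold higher number from compound 3 to compound 4 (0.31 log units; beyond the scatter): the same change on two cores in this assay, a 2.0-fold higher number (0.30 log units; within the scatter) from compound 1 to compound 2 and a 2.0-fold higher number (0.31 log units; beyond the scatter) from compound 3 to compound 4, 1.0-fold (0.01 log units) apart, within the scatter of two such steps. Nitro in place of chloro also carried across, with a 1.1-fold lower number from compound 2 to compound 4 (0.03 log units; within the scatter): the same change on two cores in this assay, a 1.1-fold lower number (0.04 log units; within the scatter) from compound 1 to compound 3 and a 1.1-fold lower number (0.03 log units; within the scatter) from compound 2 to compound 4, 1.0-fold (0.01 log units) apart, within the scatter of two such steps. Across these four compounds the two changes combine without interaction, but this does not show that the match extends to other cores or substituents, and it does not explain the steps.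

From the compounds shown here alone, whether a fluoro, a methoxy or a carboxylic acid in place of the bromo would behave the same way remains open. Going by these compounds, it is also open how an amine in place of the nitro would read.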